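The source may hold more compounds than are shown below. What is called first, only, known or untested is meant among the compounds shown, and "the series" means these compounds.

Two compounds built on a shared core were examined in a functional assay on HT-29 cells (Homo sapiens) for cytotoxicity, read by MTT assay, with a stated time of 72 h; a higher number here means a weaker inhibitor, a lower number a stronger inhibitor. Compound 1 `O=C(Nc1nc2ccc(Cl)cc2s1)c1cn(-c2ccccc2)nc1-c1ccccc1` gives 7810 nM in this assay. Compound 2 `O=C(Nc1nc2ccccc2s1)c1cn(-c2ccccc2)nc1-c1ccc(Cl)cc1` gives 13700 nM in this assay. Among the two numbers, compound 2 sits at one end, but its distance from compound 1 falls within the usual scatter of repeated measurements, so the two compounds cannot be told apart on these data.

Compound 3 `O=C(Nc1nc2ccc(Cl)cc2s1)c1cn(-c2ccccc2)nc1-c1ccc(Cl)cc1` has not yet been measured. It differs from compound 2 by chloro in place of hydrogen on an aromatic carbon. Within the data shown here, no pair of measured compounds shows this change on its own, so its effect has to be estimated. Among the measured compounds shown here, compound 1, which already carries the 6-chloro-1,3-benzothiazol-2-yl group, gives 7810 nM in this assay, and this is the only guide available.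

Compound 3 is therefore expected to give about 9000 nM in this assay, with a likely range from 4000 nM to 22000 nM. The step of a 1.5-fold lower number from compound 2 to compound 3 (0.18 log units; within the scatter) that this estimate implies is expected to remain within the scatter, with no change beyond it foreseen in either direction.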

Compound 3, half-maximal inhibitory concentration: 4550 nM
For compound 3 the middle estimate is 2.0-fold (0.30 log units) above the measured one; the measured number falls inside the stated range.
By their numbers in this assay, from the lowest: compounds 3, 1 and 2 (each within the scatter of the next, the first and the last beyond it).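

In this assay, among these compounds, replacing 1,3-benzothiazol-2-yl with 6-chloro-1,3-benzothiazol-2-yl gives a 3.0-fold lower number from compound 2 to compound 3 (0.48 log units; beyond the scatter), a modest step and the first single-place reading of chloro at this position. The earlier pair could not give this reading, as compound 1 and compound 2 differ in two places. Among the compounds shown here, the other chloro, the one that compound 3 shares with compound 2 and that compound 1 lacks, gives a 1.7-fold lower number from compound 1 to compound 3 (0.23 log units; within the scatter), so on this one background only the chloro on the six-membered aromatic ring of the fused system produces a step that can be told apart from repeat measurements. The data offer nothing that accounts for this step.

On these data alone, what remains open is whether the gain belongs to chloro itself or would also appear with another group at this position, such as fluoro, methoxy or an amine. The compounds shown also leave open how either chloro behaves on a core with hydrogen at both places, since each step here is read on a background that already carries one chloro.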